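This account rests on a few compounds, and the source may have more. Where it says the series, first, only, none or still open, it means among the compounds named here.

In a functional assay on DU-145 cells (Homo sapiens) for antiproliferative activity, read by MTT assay, with a stated time of 72 h (on this read-out lower numbers stand for stronger inhibition and higher numbers for weaker inhibition), compound 3, `O=C1OCC[C@@H]1NC(=S)SCCOc1ccccc1`, gives 63800 nM, the highest number of the three measured. Among the compounds with values here, its closest neighbour is compound 2, `O=C1OCC[C@@H]1NC(=S)SCCOc1ccc([N+](=O)[O-])cc1`, which gives 31000 nM, and the only single-point step among the measured compounds is the one in which hydrogen replaces nitro, a 2.1-fold higher number from compound 2 to compound 3 (0.31 log units; beyond the scatter). Compound 1, `O=C(COc1ccc(C(=O)/C=C/c2cccc(Cl)c2)cc1)N[C@H]1CCOC1=O`, built on a different core, gives 3700 nM and sits far from compound 3. Compound 4, `O=C1OCC[C@@H]1NC(=S)SCCOc1ccccc1Cc1ccccc1`, differs from compound 3 by benzyl in place of hydrogen on an aromatic carbon. Within the data shown here, no measured step bears directly on adding a benzyl group to this ring; the nitro step only shows that a change on this ring shifts this assay by a modest amount. The step in this assay is therefore expected to be of similar modest size, probably toward a lower number, a 2.1-fold lower number from compound 3 to compound 4 (0.33 log units; beyond the scatter), though a result within the scatter would not surprise. The estimate for compound 4 in this assay is 30000 nM, with a range from 8000 nM to 120000 nM.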

Compound 4, half-maximal inhibitory concentration: > 64000 nM
Compound 4 gave a limit, no number (the forecaster's own chance of this, stated with the estimate: 20%); at least 2.1-fold (0.32 log units) between middle value and limit.
By their numbers in this assay, from the lowest: compound 1; then compound 2; then compound 3. At a limit, above all of these: compound 4.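

In this assay compound 4 gives > 64000 nM and this is a limit of the assay, not a number. Benzyl in place of hydrogen on an aromatic carbon, ortho to a large group, gives a number no lower from compound 3 to compound 4 (the limit leaves the size open) and so brings no stronger inhibition at this place, something the nitro step on this ring could not show. How much weaker compound 4 may be cannot be read, and the result rests on the limit alone: the limit of > 64000 nM in this assay, at which 1 of the 4 values shown sits.

The compounds shown leave open whether a smaller group at this place, such as methyl, or an amine or a carboxylic acid there would give a lower number. They also leave open whether benzyl would behave the same way at the ring position that carries nitro in compound 2.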